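The source may hold more compounds than are shown below. What is called first, only, known or untested is meant among the compounds shown, and "the series" means these compounds.

Compound 1 `CC[C@H](COC)n1c(=O)c(C)nc2c(-c3ccc(Cl)cc3Cl)ncnc21` carries a 1-(methoxymethyl)propyl group on an aromatic nitrogen of its core. In a functional assay for antagonist activity at corticotropin-releasing factor receptor 1 (Rattus norvegicus) (on this read-out higher numbers stand for weaker inhibition and lower numbers for stronger inhibition), compound 1 gives 97 nM, the second highest of the three numbers available. Compound 2 `CCCC(C)n1c(=O)c(C)nc2c(-c3ccc(Cl)cc3Cl)ccnc21` gives 62 nM, within the scatter of compound 1, while compound 3 `Cc1nc2c(-c3ccc(Cl)cc3Cl)ccnc2n(C(C)C(C)C)c1=O` gives 380 nM. For the measured compounds named here, the only single-point step measured, a 6.1-fold higher number from compound 2 to compound 3 (0.79 log units; beyond the scatter), shows that branching at the saturated chain carbon bound to the aromatic nitrogen weakens inhibition.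

Compound 4 `CC[C@@H](C1CC1)n1c(=O)c(C)nc2c(-c3ccc(Cl)cc3Cl)ncnc21` differs from compound 1 in that (1-cyclopropylpropyl in place of 1-(methoxymethyl)propyl on an aromatic nitrogen). The oxygen of the 1-(methoxymethyl)propyl group leaves and a three-membered ring of carbon only enters at the chain carbon. That compound 2, with no oxygen in its group, sits within the scatter of compound 1 suggests the loss of the acceptor matters little; the added branching, judged by a 6.1-fold higher number from compound 2 to compound 3 (0.79 log units; beyond the scatter), may cost some potency. Compound 4 is therefore expected to give 130 nM, in the range 40 nM to 420 nM, a step of a 1.3-fold higher number from compound 1 to compound 4 (0.13 log units; within the scatter) that is estimated to be small and toward weaker inhibition.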

Compound 4, half-maximal inhibitory concentration: 24 nM
Compound 4: middle estimate off by 5.4-fold (0.73 log units), on the high side; the measured number lies below the stated range.
By their numbers in this assay, from the lowest: compound 4; then compounds 2 and 1 (each within the scatter of the next); then compound 3.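

On the core of compound 1, the exchange of 1-(methoxymethyl)propyl for 1-cyclopropylpropyl on the aromatic nitrogen gives in this assay a 4.0-fold lower number from compound 1 to compound 4 (0.61 log units; beyond the scatter) and so moves inhibition in the stronger direction. The result shows that this position accepts a three-membered ring of carbon at the chain carbon, and that the hydrogen-bond acceptor of the leaving group is not needed for inhibition at this level on this core. No measurement shown here accounts for the gain.

The compounds shown leave open whether the ring or the loss of the oxygen carries the step, and a 1-ethylpropyl or 1-cyclobutylpropyl group on the same core would help to separate the two. As far as these compounds go, the effect of the opposite configuration at the stereocentre of the 1-cyclopropylpropyl group also remains open.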